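This account rests on a few compounds, and the source may have more. Where it says the series, first, only, none or still open, it means among the compounds named here.

Compound 1 `Cc1c(NCc2nnc(-c3ccncc3)o2)c(=O)n(-c2ccccc2)n1C` is the starting point of this account. Among the compounds with values here, in a physicochemical assay for lipophilicity, measured as octanol-water partition (on this read-out lower numbers stand for lower lipophilicity and higher numbers for higher lipophilicity), compound 1 gives 0.8, the lowest of the two numbers measured so far; the only neighbour is compound 2 `Cc1ccc(-c2nnc(CNc3c(C)n(C)n(-c4ccccc4)c3=O)o2)cc1`, which in this assay gives 2.48. Within the data shown here, the one measured step, a number 1.68 log units higher from compound 1 to compound 2 (beyond the scatter), was large and well beyond the scatter. Compound 3 `Cc1c(NCc2nnc(-c3cccs3)o2)c(=O)n(-c2ccccc2)n1C` has not been measured in this assay. It differs from compound 1 in a single place: thiophen-2-yl in place of pyridin-4-yl on an aromatic carbon. The step from compound 1 to compound 2 bears on this change, since both replace the same pyridin-4-yl on the same aromatic carbon with a ring lacking a ring nitrogen, and because that step was a number 1.68 log units higher from compound 1 to compound 2 (beyond the scatter) a rise is expected here too, though a smaller one given the smaller ring entering. The expected step is a number 1.20 log units higher from compound 1 to compound 3 (beyond the scatter). Compound 3 is therefore estimated at 2, with a likely range from 1.5 to 2.5.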

Compound 3, partition coefficient: 1.9
The estimate for compound 3 lay 0.10 log units above the measured number; the range from low to high includes it.
By their numbers in this assay, from the lowest: compound 1; then compound 3; then compound 2.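

With thiophen-2-yl, the aromatic carbon next to the ring nitrogen and the ring oxygen gives a second replacement of pyridin-4-yl that raises the number in this assay, with a number 1.10 log units higher from compound 1 to compound 3 (beyond the scatter), so the rise no longer rests on 4-methylphenyl alone. The change from 4-methylphenyl to thiophen-2-yl also gives a separate step, a number 0.58 log units lower from compound 2 to compound 3 (beyond the scatter), which places the three groups in a clear order at this position: pyridin-4-yl, thiophen-2-yl, then 4-methylphenyl. No measurement shown here explains this order.

The compounds shown leave open how much of the 4-methylphenyl step belongs to the methyl and how much to the ring itself. They also leave open where an amine or a carboxylic acid on that same ring would fall in this order.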